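Compound 3 and the limit of the assay

The source may hold more compounds than are shown below. What is called first, only, known or untested is meant among the compounds shown, and "the series" means these compounds.

compound 1 `CNc1nc(N)nc2c1ncn2/C=C1/CC1(CO)CO` gives > 20000 nM
compound 2 `CCCNc1nc(N)nc2c1ncn2/C=C1/CC1(CO)CO` gives "not determined" (no result reported)

These two compounds share a core and differ in the chain on one aromatic carbon. In an ADME assay on MOLT-3 cells (Homo sapiens) for cytotoxicity, with a stated time of 7 days (a lower number here means that less compound is tolerated, a higher number that more compound is tolerated), compound 1 stands at the limit of > 20000 nM in this assay, at which 1 of the 2 values shown sits, and so gives no exact number. Compound 2 has no number at all: its entry reads "not determined" (no result reported) and it cannot be placed on the scale.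

The next compound is compound 3 `CCCCCOc1nc(N)nc2c1ncn2/C=C1/CC1(CO)CO` and its structural change is pentyloxy in place of propylamino on an aromatic carbon with pentyloxy in place of propylamino on an aromatic carbon. Among the measured compounds shown here, no measured pair in this small set shows what such a swap does. For the measured compounds named here, the only guide is compound 1, whose > 20000 nM is a limit and not a number. With so little to go on, no step beyond the usual scatter is expected in this assay and no direction can be favoured. For compound 3 the estimated value is 20000 nM with an expected range from 8000 nM to 40000 nM around it.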

Compound 3, half-maximal cytotoxic concentration: > 20000 nM
Compound 3: only a limit was reported; the forecaster's own chance of this, stated with the estimate: 70%; the middle value sits exactly at the limit.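

Compound 1 and compound 3 both end at a limit and not at an exact number, so the step between them cannot be read: the limit of > 20000 nM in this assay, at which 2 of the 3 values shown sit.

On these data alone, what stays open is whether pentyloxy in place of methylamino on the aromatic carbon changes anything in this assay, and where compound 2 stands on that scale.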